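The source may report more compounds than this note shows. Statements on the series, on what has been measured and on what is new or still open speak of the compounds shown alone.

Values so far in a functional assay on the whole organism with Rattus norvegicus as the target; a lower number here means that less compound is needed, a higher number that more compound is needed for the effect
compound 1 `CCN1CCCC1CNC(=O)c1cc(Cl)c(N)cc1OC` gives > 30 mg/kg
compound 2 `CCN1C(CNC(=O)c2cc(Cl)c(NC)cc2OC)CCC1c1ccccc1` gives > 30 mg/kg
compound 3 `CCCNc1cc(OC)c(C(=O)NC2CCN(Cc3ccccc3)C2)cc1Cl` gives 17 mg/kg

Compound 1 has an entry (> 30 mg/kg) that is a limit of the assay and not a number. The entry for compound 2 (> 30 mg/kg) is likewise a limit. Among the compounds with values here, compound 3 (17 mg/kg) therefore holds the only true number, and it is the sole anchor for anything that follows.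

Compound 4 `COc1cc(NC=O)c(Cl)cc1C(=O)NC1CCN(Cc2ccccc2)C1` has not yet been measured. It departs from compound 3 in one place (formyl in place of propyl on a nitrogen on an aromatic ring), with formyl in place of propyl on a nitrogen on an aromatic ring. Within the data shown here, no measured step between compounds differing in one place exists, so the size of this change in this assay cannot be read from the series. The record does show (the limit of > 30 mg/kg in this assay, at which 2 of the 3 values shown sit), which leaves the upper side of the range more likely than the lower. The expected step (a 1.8-fold higher number from compound 3 to compound 4 (0.25 log units; within the scatter)) points toward more compound being needed, but it is expected to stay within the usual scatter. For compound 4 the estimated dose is 30 mg/kg, with an expected range from 12 mg/kg to 75 mg/kg, and a reading that gives only a limit would be no surprise.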

Compound 4, dose for half-maximal effect: 0.6 mg/kg
The estimate for compound 4 lay 50-fold (1.70 log units) above the measured number; the whole stated range lies above it.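

Placing formyl in place of propyl on a nitrogen on an aromatic ring gives a 28-fold lower number from compound 3 to compound 4 (1.45 log units; beyond the scatter) in this assay; it is the first step in the series that can be read, and it shows that the result is highly sensitive to the group at this place. Compounds 1 and 2 could not show this, since each differs from compound 3 in more than one place, and the change here swaps a chain of three carbons for a smaller group that carries a carbonyl and one hydrogen-bond acceptor. Compound 4 also gives a true number far from the ceiling that holds much of the series: the limit of > 30 mg/kg in this assay, at which 2 of the 4 values shown sit.

A single pair cannot tell whether the carbonyl, the hydrogen-bond acceptor or the smaller size of the group accounts for the step, and an acetyl group or an ethyl chain on the same nitrogen would help to separate these. From the compounds shown here alone, it also remains open whether formyl would have a similar effect on the side chain of compound 1 or compound 2.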